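Ethoxymethyl for methyl on the core of compound 2

The compounds below may be only part of what the source reports. "The series", "measured", "known", "first", "only" and "open" are said of these compounds alone.

Two compounds of the series have numbers in an assay on Cerebral cortex for displacement of a labelled ligand from adenosine receptor A1 (Bos taurus) (a lower number here means a stronger inhibitor, a higher number a weaker inhibitor), so far. Compound 1 `CCCn1c(=O)c2nc(C3CCCC3)[nH]c2n(/C=C/CI)c1=O` gives 0.237 nM in this assay. Compound 2 `CCCn1c(=O)n(C)c(=O)c2[nH]c(C3CCCC3)nc21` gives 0.526 nM in this assay, the higher of the two numbers; the gap to compound 1 lies beyond the usual scatter, but the two compounds differ in more than one place, so the pair tells nothing about a single structural change.

The next compound to be measured is compound 3 `CCCn1c(=O)n(COCC)c(=O)c2[nH]c(C3CCCC3)nc21`. Relative to compound 2 the change is ethoxy in place of hydrogen on a saturated chain carbon bound to an aromatic nitrogen. Among the measured compounds shown here, no pair of measured compounds isolates a change of this kind, so the direction of the step rests on the structural change alone.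

The expectation for this assay is a step from compound 2 to compound 3 of a 1.2-fold lower number from compound 2 to compound 3 (0.07 log units; within the scatter), that is, no step beyond the scatter in either direction. Compound 3 is therefore estimated at 0.45 nM in this assay, with a range from 0.15 nM to 1.3 nM.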

Compound 3, inhibition constant: 0.286 nM
The estimate for compound 3 lay 1.6-fold (0.20 log units) above the measured number; low and high end bracket the measured number.
By their numbers in this assay, from the lowest: compounds 1, 3 and 2 (each within the scatter of the next, the first and the last beyond it).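

In this assay the series now has its first step that isolates a single change: methyl to ethoxymethyl on the core of compound 2 (a 1.8-fold lower number from compound 2 to compound 3 (0.26 log units; within the scatter)). On a saturated chain carbon bound to an aromatic nitrogen, ethoxy in place of hydrogen adds 3 heavy atoms and 1 hydrogen-bond acceptor, yet the number stays within the scatter of compound 2, so this position tolerates at least this one larger group without a readable loss or gain. No independent measurement bears on this result, and the step stands as an observation only.

As far as these compounds go, a single substituent cannot define the limits of this position, so it remains open whether a longer chain, a terminal hydroxyl or an amine in place of ethoxy would also hold the number in this assay. From the compounds shown here alone, it is equally open whether the same change would read alike if the propyl chain or the cyclopentyl group of compound 2 were replaced.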